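Swapping an amide for a sulfonamide on a shared core

The source may hold more compounds than are shown below. What is called first, only, known or untested is meant among the compounds shown, and "the series" means these compounds.

Compound 3 `O=C(C1CCCCO1)N1CCc2nc(C#Cc3ccccc3)sc2C1` belongs to a small set built on one shared core. In an assay on HEK293 cells for negative allosteric modulation of metabotropic glutamate receptor 5 (Homo sapiens), read by FLIPR, with a stated time of 1 h (a higher number here means a weaker inhibitor, a lower number a stronger inhibitor), compound 3 gives > 10000 nM, which is a limit of the assay rather than a number. Compound 1 `O=C(C1CCCC1)N1CCc2nc(C#Cc3ccccc3)sc2C1` gives > 10000 nM in this assay, again only a limit. Compound 2 `O=C(C1CCCO1)N1CCc2nc(C#Cc3ccccc3)sc2C1` gives > 10000 nM in this assay, also a limit. All three sit at the limit of > 10000 nM in this assay, at which 3 of the 3 values shown sit, so none of the steps among them can be sized: a step that the two limits leave unreadable from compound 1 to compound 2, a step that the two limits leave unreadable from compound 1 to compound 3 and a step that the two limits leave unreadable from compound 2 to compound 3 are all unreadable. Compound 3 thus stands with the others at the limit, with nothing to set it apart.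

Compound 4 `CC(C)S(=O)(=O)N1CCc2nc(C#Cc3ccccc3)sc2C1` is not yet measured. It differs from compound 3 in one place: isopropylsulfonyl in place of (oxan-2-yl)carbonyl on an amine nitrogen in a ring. For the measured compounds named here, no measured step touches a change at this nitrogen, and the steps that exist, all between limits, give no direction to carry forward. The expectation for compound 4 in this assay therefore cannot lean on any readable step, and its estimated step of a number no higher from compound 3 to compound 4 (the limit leaves the size open) is set at no change beyond the scatter. Compound 4 is expected to give about 10000 nM, with a range from 2000 nM to 50000 nM, and most likely it will again be reported only as a limit.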

Compound 4, half-maximal inhibitory concentration: 11 nM
For compound 4 the middle estimate is 910-fold (2.96 log units) above the measured one, and the stated range ends above it.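

The nitrogen that carries these groups turns out to be highly sensitive to what sits on it, which the earlier compounds could not show, as the steps among compound 1, compound 2 and compound 3 cannot be read and all three rest at a limit of the assay: the limit of > 10000 nM in this assay, at which 3 of the 4 values shown sit.

In this assay, isopropylsulfonyl on this amine nitrogen gives an at least 900-fold lower number from compound 3 to compound 4 (2.95 log units; beyond the scatter) against (oxan-2-yl)carbonyl, an at least 900-fold lower number from compound 2 to compound 4 (2.95 log units; beyond the scatter) against (oxolan-2-yl)carbonyl and an at least 900-fold lower number from compound 1 to compound 4 (2.95 log units; beyond the scatter) against cyclopentylcarbonyl. The shared core can therefore give a strong inhibitor in this assay, and the outcome holds against all three carbonyl groups shown, whether their ring contains oxygen or not.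

This single change replaces the carbonyl with a sulfonyl and also replaces a ring-bearing group with one that has no ring, so the compounds shown cannot tell which of the two matters. A cyclopentylsulfonyl group or an isopropylcarbonyl group on this nitrogen would separate the two, and a methylsulfonyl group or a longer chain on the sulfonyl would show how much room for variation the sulfonyl series has.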